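The source may hold more compounds than are shown below. What is called first, only, known or untested is meant among the compounds shown, and "the series" means these compounds.

Measured so far in an assay on isolated protein for inhibition of Gonadotropin-releasing hormone receptor (Rattus norvegicus); on this read-out higher numbers stand for weaker inhibition and lower numbers for stronger inhibition:
compound 1 `CCCCn1c(SCc2cc([N+](=O)[O-])ccc2OC)nc2cc(NC(=O)NC(C)(C)C)ccc21`: 330 nM
compound 2 `CCCCCn1c(SCc2cc([N+](=O)[O-])ccc2OC)nc2cc(NC(=O)NC(C)(C)C)ccc21`: 880 nM

Among the measured compounds shown here, compound 2 holds the higher of the two numbers, with compound 1 the nearest point; the single step between them, a 2.7-fold higher number from compound 1 to compound 2 (0.43 log units; beyond the scatter), is the only one in hand for this series.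

Compound 3 `COc1ccc([N+](=O)[O-])cc1CSc1nc2cc(NC(=O)NC(C)(C)C)ccc2n1Cc1ccccn1` is not yet measured. Relative to compound 2 the change is pyridin-2-yl in place of butyl on a saturated chain carbon bound to an aromatic nitrogen. For the measured compounds named here, no measured step shows an aromatic ring entering at that position. Going by the values given here, the one step in hand, a 2.7-fold higher number from compound 1 to compound 2 (0.43 log units; beyond the scatter), concerns only the lengthening of the chain by one carbon at the same region, so it speaks to the position but not to the kind of change now made. Among the compounds with values here, with no direct precedent, the expectation in this assay for compound 3 rests on that step being modest: a change of moderate size at most, with no firm basis to prefer one direction, and a wide range to cover the missing precedent.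

The estimate for compound 3 in this assay is 500 nM, between 120 nM and 2500 nM. The step this estimate implies, a 1.8-fold lower number from compound 2 to compound 3 (0.25 log units; within the scatter), is expected to sit close to the scatter.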

Compound 3, half-maximal inhibitory concentration: 670 nM
Beside the measured number, compound 3's estimate is 1.3-fold (0.13 log units) below it, within the range that was stated.
By their numbers in this assay, from the lowest: compound 1; then compounds 3 and 2 (each within the scatter of the next).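

In this assay the saturated chain carbon bound to an aromatic nitrogen tolerates an aromatic ring: pyridin-2-yl in place of butyl gives a 1.3-fold lower number from compound 2 to compound 3 (0.12 log units; within the scatter) and so leaves compound 3 level with compound 2, even though the change brings in a six-membered aromatic ring with a hetero atom. Measured against the shorter chain, the same position gives a 2.0-fold higher number from compound 1 to compound 3 (0.31 log units; beyond the scatter) as a modest step, and compound 1 keeps the lowest number of the three, so neither pentyl nor (pyridin-2-yl)methyl at this place matches the chain of compound 1. Nothing at hand gives a reason for either step.

The compounds shown do not separate the effect of the ring nitrogen from that of the ring itself, a question that a benzyl group in place of (pyridin-2-yl)methyl would address. On these data alone, it also remains open how an ethyl chain, or a chain ending in a dimethylamino group, would read at this place in this assay on the same core.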